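Furan in Place of Chlorophenyl on the Amide Carbonyl

The compounds below may be only part of what the source reports. "The series", "measured", "known", "first", "only" and "open" are said of these compounds alone.

Of the compounds shown here, three built on one shared core have been measured. Compound 1 `COCC(=O)Nc1c(C(O)(C(F)(F)F)C(F)(F)F)ccc2ccccc12` gives 93% in a functional assay (Sus scrofa) with sulfonylurea receptors; K-ATP channels (Homo sapiens) as the target (on this read-out higher numbers stand for larger maximal responses and lower numbers for smaller maximal responses), compound 2 `Cc1cccc(C(=O)Nc2c(C(O)(C(F)(F)F)C(F)(F)F)ccc3ccccc23)c1` gives 97%, and compound 3 `O=C(Nc1c(C(O)(C(F)(F)F)C(F)(F)F)ccc2ccccc12)c1ccc(Cl)cc1` gives 99%. Compound 3 carries the highest of the three numbers, but only by steps inside the scatter: a number 2 percentage points higher from compound 2 to compound 3 (within the scatter) and a number 6 percentage points higher from compound 1 to compound 3 (within the scatter). Compound 4 `O=C(Nc1c(C(O)(C(F)(F)F)C(F)(F)F)ccc2ccccc12)c1ccco1` differs from compound 3 in one place: furan-2-yl in place of 4-chlorophenyl on a carbonyl carbon. Among the measured compounds shown here, the steps that bear on this change all altered the group on the same carbonyl carbon, namely a number 4 percentage points higher from compound 1 to compound 2 (within the scatter), a number 6 percentage points higher from compound 1 to compound 3 (within the scatter) and a number 2 percentage points higher from compound 2 to compound 3 (within the scatter), and none left the scatter. Compound 4 is therefore expected to show no step beyond the scatter, a number 4 percentage points lower from compound 3 to compound 4 (within the scatter). The estimate for compound 4 is 95%, expected to fall between 84% and 104%.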

Compound 4, largest response reached (reported as efficacy), in percent of the reference or control that the assay uses: 96%
Beside the measured number, compound 4's estimate is 1 percentage points below it; the measured number falls inside the stated range.
By their numbers in this assay, from the lowest: compounds 1, 4, 2 and 3 (each within the scatter of the next).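

In this assay furan-2-yl on the carbonyl carbon brings a number 3 percentage points lower from compound 3 to compound 4 (within the scatter) and a number 1 percentage points lower from compound 2 to compound 4 (within the scatter) and a number 3 percentage points higher from compound 1 to compound 4 (within the scatter) as the group it replaces changes from 4-chlorophenyl to 3-methylphenyl to methoxymethyl. A five-membered aromatic ring with one hetero atom therefore joins the six-membered aromatic rings and the methoxymethyl chain, and no step among these groups leaves the scatter. No evidence is available on what lies behind this result.

Going by these compounds, it remains open whether any group at this position can move the maximal response beyond the scatter. An amine, a carboxylic acid or a longer chain on this carbonyl carbon could test that.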